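Chloropurine benzyl series: one chloro fewer on the core

The compounds below may be only part of what the source reports. "The series", "measured", "known", "first", "only" and "open" are said of these compounds alone.

Two compounds carry a benzyl bearing a chloromethyl on the same fused core. Compound 1 `ClCc1ccc(Cn2cnc3c(Cl)ncnc32)cc1` has a single chloro on the core and the chloromethyl para on the benzyl; in a functional assay on SN12C cells (Homo sapiens) for cytotoxicity, read by sulforhodamine B assay, with a stated time of 48 h (on this read-out higher numbers stand for lower toxicity in this test and lower numbers for higher toxicity in this test), compound 1 gives 5370 nM. Compound 2 `ClCc1ccccc1Cn1cnc2c(Cl)nc(Cl)nc21` has two chloro groups on the core and the chloromethyl ortho on the benzyl; in this assay compound 2 gives 4670 nM, and the gap to compound 1 is within the scatter, so the two numbers cannot be told apart.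

Compound 3 `ClCc1ccccc1Cn1cnc2c(Cl)ncnc21` is compound 2 with one chloro taken off the core: hydrogen in place of chloro on an aromatic carbon. Within the data shown here, no measured pair shows this change directly. Compound 1 already shows that a single chloro on the core gives a number in the same band as compound 2, so the step from compound 2 to compound 3 is expected to stay within the scatter, with no clear direction, a 1.3-fold higher number from compound 2 to compound 3 (0.11 log units; within the scatter). Compound 3 is therefore estimated at 6000 nM, with a range from 2500 nM to 15000 nM.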

Compound 3, concentration lethal to 50% of the cells: 95500 nM
Compound 3: the middle estimate sits 16-fold (1.20 log units) below what was measured, and the stated range ends below it.
By their numbers in this assay, from the lowest: compounds 2 and 1 (each within the scatter of the next); then compound 3.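

On the aromatic carbon between two ring nitrogen atoms, the chloro counts for a great deal in this series: the change to hydrogen gives a 20-fold higher number from compound 2 to compound 3 (1.31 log units; beyond the scatter) in this assay, which on this read-out means much lower toxicity in this test. A single chloro on the core does not by itself set the number, since compound 1 gives 5370 nM and compound 3 gives 95500 nM with the same core, the two differing only in where the chloromethyl sits on the benzyl; the closeness of compound 1 and compound 2 therefore gave no sign of what this chloro contributes. No measurement at hand accounts for the size of this step.

Still open, on these data alone, is whether this carbon needs a chloro specifically, or whether an amine or a methoxy group there would keep the number near that of compound 2 or leave it near that of compound 3. Among these compounds, also open is whether the same chloro would matter as much with the chloromethyl placed as in compound 1, as the only step available carries the chloromethyl placed as in compound 2.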